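The compounds below may be only part of what the source reports. "The series", "measured", "known", "first", "only" and "open" are said of these compounds alone.

Working notes on the series. In a functional assay on B16 cells (Mus musculus) for inhibition (on this read-out higher numbers stand for weaker inhibition and lower numbers for stronger inhibition), compound 1 (`COc1cc(/C=C/C(=O)c2cccc(NC(=O)c3ccco3)c2)ccc1O`) gives 5.46 ug/mL and compound 2 (`COc1cc(/C=C/C(=O)c2cccc(NC(=O)c3ccc(Cl)c(Cl)c3)c2)ccc1O`) gives 3.88 ug/mL. Compound 2 therefore stands within the scatter of compound 1, and the two numbers cannot be ranked.

Compound 3 (`CCOC(=O)C(=O)Nc1cccc(C(=O)/C=C/c2ccc(O)c(OC)c2)c1`) has not yet been measured. Compared with compound 2, it carries ethoxycarbonyl in place of 3,4-dichlorophenyl on a carbonyl carbon whose other neighbour is an amide-type nitrogen: ethoxycarbonyl in place of 3,4-dichlorophenyl on a carbonyl carbon.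

Going by the values given here, one measured step bears on this change, a 1.4-fold lower number from compound 1 to compound 2 (0.15 log units; within the scatter), where 3,4-dichlorophenyl replaced furan-2-yl on the same carbonyl carbon. That step was small and stayed within the scatter. Among the compounds with values here, it exchanges one ring for another, however, and no measured compound has a group without a ring at this place, so the evidence is thin and the range must stay wide.

No step beyond the scatter is expected in this assay, and no direction can be firmly assigned. The estimated step is a 1.3-fold higher number from compound 2 to compound 3 (0.11 log units; within the scatter). For compound 3 the expected value is 5 ug/mL, with an estimated range of 2 ug/mL to 12 ug/mL.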

Compound 3, half-maximal inhibitory concentration: 7.03 ug/mL
Beside the measured number, compound 3's estimate is 1.4-fold (0.15 log units) below it, and the stated range covers the measured number.
By their numbers in this assay, from the lowest: compounds 2, 1 and 3 (each within the scatter of the next).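

Among the compounds shown, ethoxycarbonyl is the only group without a ring on this carbonyl carbon, and in this assay it gives a 1.8-fold higher number from compound 2 to compound 3 (0.26 log units; within the scatter) and a 1.3-fold higher number from compound 1 to compound 3 (0.11 log units; within the scatter) for the same change from furan-2-yl. A ring at this place is therefore not required for a number in this range: the three compounds cannot be ranked, although the group changes from an aromatic ring to an open group with 2 hydrogen-bond acceptors. No measurement at hand offers an explanation for how closely these numbers lie.

It remains open whether any group on this carbonyl carbon can move the number beyond the scatter, since all three groups shown leave it within the scatter. A carboxylic acid in place of the ethoxycarbonyl, an amine or a longer alkyl chain at this place would test that, while the compounds shown say nothing about changes elsewhere on the shared core.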